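Amino acid ester in place of propanoyl on compound 1

The source may report more compounds than this note shows. Statements on the series, on what has been measured and on what is new or still open speak of the compounds shown alone.

Measured compounds:
Compound 1, `CCOC(=O)C1=C(S[C@@H]2CN[C@H](C(=O)Nc3cccc(C(=O)OCC)c3)C2)[C@H](C)[C@@H]2[C@@H]([C@@H](C)OC(=O)CC)C(=O)N12`, oral bioavailability 12.6%.
Compound 2, `CC(C)C(=O)OCOC(=O)C1=C(S[C@@H]2CN[C@H](C(=O)Nc3cccc(C(=O)OCOC(=O)C(C)C)c3)C2)[C@H](C)[C@@H]2[C@@H]([C@@H](C)O)C(=O)N12`, oral bioavailability 3.6%.
Compound 3, `CCCOC(=O)C1=C(S[C@@H]2CN[C@H](C(=O)Nc3cccc(C(=O)OCCC)c3)C2)[C@H](C)[C@@H]2[C@@H]([C@@H](C)O)C(=O)N12`, oral bioavailability 9.8%.

The three compounds share one core and were compared in an ADME assay on the whole organism (strain Beagle) for pharmacokinetics, with Canis familiaris (Canis lupus familiaris) as the target, read by LC-MS, at a dose of 10 mg/kg; a higher number here means that a larger share of the oral dose reaches the circulation, a lower number that a smaller share of the oral dose reaches the circulation. Compound 1 gives 12.6%, and this number is the largest of the three; the gap to compound 3 and the gap to compound 2 both lie within the usual scatter of the method, so the three cannot be set apart on these data. Going by the values given here, no pair of them differs in one place only, so no single change can be read from the measured set.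

Compound 4, `CCOC(=O)C1=C(S[C@@H]2CN[C@H](C(=O)Nc3cccc(C(=O)OCC)c3)C2)[C@H](C)[C@@H]2[C@@H]([C@@H](C)OC(=O)[C@@H](N)C(C)C)C(=O)N12`, has not yet been measured. It differs from compound 1 in one place: 1-amino-2-methylpropyl in place of ethyl on a carbonyl carbon. For the step from compound 1 to compound 4 in this assay a modest rise is expected, though one not clearly beyond the scatter, because compound 1 already gives 12.6% and nothing in the measured set shows a change of this kind. Compound 4 is therefore expected to give about 20%, with a range from 8% to 40%, an expected step of a number 7.4 percentage points higher from compound 1 to compound 4 (within the scatter).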

Compound 4, oral bioavailability: 9.7%
For compound 4 the middle estimate is 10.3 percentage points above the measured one, within the range that was stated.
By their numbers in this assay, from the lowest: compounds 2, 4, 3 and 1 (each within the scatter of the next).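

In this assay, putting 1-amino-2-methylpropyl in place of ethyl on a carbonyl carbon gives a number 2.9 percentage points lower from compound 1 to compound 4 (within the scatter), so the two compounds cannot be set apart on these data. This is the only pair shown that differs in one place, and it adds a first direct reading for this position: a larger group of 5 heavy atoms, with an amine and a defined stereocentre, replaces the 2 heavy atoms of ethyl without a step beyond the scatter. Nothing available here explains this result.

On these data alone, it remains open whether a shorter 1-aminoethyl group or a chain ending in a carboxylic acid would give a step beyond the scatter at this position. The opposite configuration at the new stereocentre also remains an open question.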